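Moving the Methoxy Group from Compound 3 to Compound 4

The source may hold more compounds than are shown below. What is called first, only, known or untested is meant among the compounds shown, and "the series" means these compounds.

In an ADME assay on HepG2 2.2.15 cells (Homo sapiens) for cytotoxicity, read by CCK-8 assay, with a stated time of 8 days (on this read-out higher numbers stand for lower toxicity in this test and lower numbers for higher toxicity in this test), compound 1 `COc1ccc(O)c(C(=O)Nc2c[nH]c(=O)c(-c3cccc(C)c3)c2)c1` gives 30100 nM and compound 2 `CCOc1ccc(-c2cc(NC(=O)c3ccccc3O)c[nH]c2=O)cc1` gives 41000 nM in the same test. Compound 3 `CCOc1ccc(-c2cc(NC(=O)c3ccc(OC)cc3O)c[nH]c2=O)cc1` reads 69600 nM here, which lies within the scatter of compound 2 and beyond the scatter from compound 1. Compound 4 `CCOc1ccc(-c2cc(NC(=O)c3cc(OC)ccc3O)c[nH]c2=O)cc1` carries the same atoms joined differently, with 2-hydroxy-5-methoxyphenyl in place of 2-hydroxy-4-methoxyphenyl on a carbonyl carbon as the whole change. Within the data shown here, the one measured step involving this methoxy group, a 1.7-fold higher number from compound 2 to compound 3 (0.23 log units; within the scatter) on its addition, stays within the scatter, and no measured pair shows the group moved. No step beyond the scatter is therefore expected in this assay for this change. The expected step is a 1.3-fold lower number from compound 3 to compound 4 (0.10 log units; within the scatter) on this estimate. Compound 4 is estimated at 55000 nM with an expected range from 28000 nM to 105000 nM in this test.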

Compound 4, half-maximal cytotoxic concentration: 57700 nM
The estimate for compound 4 lay 1.0-fold (0.02 log units) below the measured number; low and high end bracket the measured number.
By their numbers in this assay, from the lowest: compounds 1, 2, 4 and 3 (each within the scatter of the next, the first and the last beyond it).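

In this assay, the first measured move of the methoxy group, with 2-hydroxy-5-methoxyphenyl in place of 2-hydroxy-4-methoxyphenyl on a carbonyl carbon, stays within the scatter (a 1.2-fold lower number from compound 3 to compound 4 (0.08 log units; within the scatter)). Adding methoxy in this new place also stays within it (a 1.4-fold higher number from compound 2 to compound 4 (0.15 log units; within the scatter)), as does 4-ethoxyphenyl in place of 3-methylphenyl (a 1.9-fold higher number from compound 1 to compound 4 (0.28 log units; within the scatter)). Nothing available explains these readings. From the compounds shown here alone, whether an amine or a carboxylic acid in place of the methoxy group would move the number beyond the scatter remains open. The same holds for a longer chain in place of the ethoxy group.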